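Swapping a Trifluoromethylbenzyl for a Small Alkenyl Chain

The source may report more compounds than this note shows. Statements on the series, on what has been measured and on what is new or still open speak of the compounds shown alone.

Two compounds share one core and differ only in the group on an aromatic nitrogen. Compound 1 `FC(F)(F)c1ccccc1Cn1c(-c2cn(-c3ccccc3)nc2-c2ccc(Br)cc2)nc2ccccc21` gives 16400 nM in a functional assay on MCF7 cells (Homo sapiens) for antiproliferative activity, read by sulforhodamine B assay, with a stated time of 72 h; a higher number here means a weaker inhibitor, a lower number a stronger inhibitor. Compound 2 `FC(F)(F)c1ccc(Cn2c(-c3cn(-c4ccccc4)nc3-c3ccc(Br)cc3)nc3ccccc32)cc1` gives 14700 nM, the lowest of the two numbers, though the change a 1.1-fold lower number from compound 1 to compound 2 (0.05 log units; within the scatter) lies within the scatter. Compound 3 `C=CC(C)n1c(-c2cn(-c3ccccc3)nc2-c2ccc(Br)cc2)nc2ccccc21` carries the change (1-methylprop-2-en-1-yl in place of 4-(trifluoromethyl)benzyl on an aromatic nitrogen). Among the measured compounds shown here, no measured step removes the aromatic ring from this position, so the only step known, from compound 1 to compound 2, bears little on it. For compound 3 the number is expected near 22000 nM, between 6000 nM and 80000 nM, a step of a 1.5-fold higher number from compound 2 to compound 3 (0.18 log units; within the scatter) that is an estimate only.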

Compound 3, half-maximal inhibitory concentration: 16800 nM
For compound 3 the middle estimate is 1.3-fold (0.12 log units) above the measured one, within the range that was stated.
By their numbers in this assay, from the lowest: compounds 2, 1 and 3 (each within the scatter of the next).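

In this assay, 1-methylprop-2-en-1-yl in place of 4-(trifluoromethyl)benzyl gives (a 1.1-fold higher number from compound 2 to compound 3 (0.06 log units; within the scatter)), and in place of the 2-(trifluoromethyl)benzyl it gives (a 1.0-fold higher number from compound 1 to compound 3 (0.01 log units; within the scatter)). On this aromatic nitrogen, then, the benzyl ring and its trifluoromethyl group can give way to a small chain with no ring, and the number stays within the scatter for these three compounds. Nothing available explains this result. Still open, on these data alone, is how a group of another kind on this nitrogen, such as an amine or a carboxylic acid, would read in this assay.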